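The compounds below may be only part of what the source reports. "The series", "measured", "known", "first", "only" and "open" are said of these compounds alone.

Going by the values given here, compound 2 `Cc1cc2c(-c3ccccc3)c(NC(=O)N(C)Cc3ccccc3Cl)n(C)c(=O)c2cc1C` gives 4.2 nM in an assay on IM-9 cells for binding affinity to Substance-P receptor (Homo sapiens) (on this read-out higher numbers stand for weaker inhibition and lower numbers for stronger inhibition), the lowest of the two numbers so far; compound 1 `CCN(Cc1ccccc1)C(=O)Nc1c(-c2ccccc2)c2cc(C)c(C)cc2c(=O)n1C` gives 66 nM. Among the compounds with values here, the one measured step, a 16-fold lower number from compound 1 to compound 2 (1.20 log units; beyond the scatter), is the only one that bears on the series here. Compound 3 `COc1ccccc1CN(C)C(=O)Nc1c(-c2ccccc2)c2cc(C)c(C)cc2c(=O)n1C` differs from compound 2 by methoxy in place of chloro on an aromatic carbon. Within the data shown here, no measured pair compares these two groups at the same carbon, so the size of that step is uncertain; a substituted benzyl group is kept in both. Compound 3 is therefore expected to stay near compound 2, with a step of a 1.9-fold higher number from compound 2 to compound 3 (0.28 log units; within the scatter), most likely a modestly higher number. The estimate for compound 3 is 8 nM, between 3 nM and 25 nM.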

Compound 3, half-maximal inhibitory concentration: 23 nM
Estimate against measurement, compound 3: 2.9-fold (0.46 log units) below; low and high end bracket the measured number.
By their numbers in this assay, from the lowest: compound 2; then compound 3; then compound 1.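

In this assay, the substituent on this aromatic carbon is not interchangeable: methoxy in place of chloro gives a 5.5-fold higher number from compound 2 to compound 3 (0.74 log units; beyond the scatter) and loses much of the 2-chlorobenzyl result. The 2-methoxybenzyl group with methyl on the nitrogen still gives a 2.9-fold lower number from compound 1 to compound 3 (0.46 log units; beyond the scatter) against benzyl(ethyl)amino, but that step changes both the ring substituent and the nitrogen chain. Nothing available accounts for the difference between chloro and methoxy here.

Open, going by these compounds, is how much of either step belongs to the ring substituent alone, which benzyl(methyl)amino would separate from the change from ethyl to methyl. Also open, on these data alone, is whether fluoro or methyl on the same carbon would track chloro or methoxy.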